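The source may hold more compounds than are shown below. What is called first, only, known or untested is meant among the compounds shown, and "the series" means these compounds.

Measured so far in a functional assay on HCT-116 cells (Homo sapiens) for cytotoxicity, read by sulforhodamine B assay, with a stated time of 72 h; on this read-out lower numbers stand for stronger inhibition and higher numbers for weaker inhibition:
- compound 1 `CCS(=O)(=O)Nc1cc(-c2ccc3ncnc(Nc4ccc(OC)cc4)c3c2)cnc1OC` gives 3490 nM
- compound 2 `CCCCS(=O)(=O)Nc1cc(-c2ccc3ncnc(Nc4ccc(F)c(Cl)c4)c3c2)cnc1OC` gives 9990 nM
- compound 3 `COC(=O)c1cccc(Nc2ncnc3ccc(-c4cnc(OC)c(NS(=O)(=O)c5ccc(F)cc5F)c4)cc23)c1` gives 1500 nM

Compound 1 stands second highest of the three numbers in this assay. Its nearest neighbour is compound 3, whose number is lower, and the gap between the two lies beyond the scatter. Its furthest neighbour is compound 2, whose number is higher, again by a gap beyond the scatter. The three compounds differ from one another in more than one place, so none of these gaps can be tied to a single structural change.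

Compound 4 `CCS(=O)(=O)Nc1cc(-c2ccc3ncnc(Nc4ccc(OC)nc4)c3c2)cnc1OC` has not yet been measured in this assay. It differs from compound 1 in one place: 6-methoxypyridin-3-yl in place of 4-methoxyphenyl on a nitrogen on an aromatic ring. The rest of the shared core, the sulfonamide chain and the methoxy group on the pyridine ring next to it are unchanged.

Going by the values given here, no single-point step between measured compounds is available, so the size of this change can only be guessed. Since the group that leaves and the group that enters match in heavy-atom count and differ only in one ring atom, the step from compound 1 to compound 4 is expected to be small, plausibly none beyond the scatter, with no firm direction: expected a 1.0-fold higher number from compound 1 to compound 4 (0.00 log units; within the scatter). On that basis compound 4 is estimated at 3500 nM in this assay, with a range from 1200 nM to 10000 nM.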

Compound 4, half-maximal inhibitory concentration: 6910 nM
The estimate for compound 4 lay 2.0-fold (0.30 log units) below the measured number, within the range that was stated.
By their numbers in this assay, from the lowest: compound 3; then compounds 1, 4 and 2 (each within the scatter of the next, the first and the last beyond it).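

In this assay the series now has its first comparison that differs in one place, a 2.0-fold higher number from compound 1 to compound 4 (0.30 log units; within the scatter), with 6-methoxypyridin-3-yl in place of 4-methoxyphenyl on a nitrogen on an aromatic ring. That step lies within the scatter, so the exchange of one ring carbon for a ring nitrogen, which raises the count of hydrogen-bond acceptors in the group, gives no difference that this read-out can separate, and compound 1 and compound 4 are best read as a single level for now. No supporting data accompany this pair, so nothing can be said about what lies behind the reading.

From the compounds shown here alone, a single pair says little about how much change this place allows: whether an ethoxy group or an amine in place of the methoxy group on the pyridine ring of compound 4 would stay within the scatter remains open. Compound 2 and compound 3 each differ from compound 1 in more than one place, so the separate contributions of the sulfonamide chain and the group on the nitrogen remain unresolved.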